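Swapping the aryl group on a fused bicyclic core

The compounds below may be only part of what the source reports. "The series", "measured", "known", "first", "only" and "open" are said of these compounds alone.

Measured so far:
Compound 1, `C=C(Br)C(=O)Nc1cccc(-c2cn3nc(-c4ccc(CC)cc4)sc3n2)c1`: 2200 nM
Compound 2, `COc1ccc(-c2csc3nc(-c4cccc(N)c4)cn23)cc1`: 19000 nM

Of the compounds shown here, two have been measured in a functional assay on L1210 cells (Mus musculus) for inhibition, read by cell counting, with a stated time of 2 days; on this read-out lower numbers stand for stronger inhibition and higher numbers for weaker inhibition. Compound 1 gives the lower of the two numbers, 2200 nM, while compound 2 gives 19000 nM, a gap that lies beyond the scatter of this assay. The two compounds differ in more than one place, so no single step can be read from them.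

Compound 3, `C=C(Br)C(=O)Nc1cccc(-c2cn3nc(-c4ccc(OC)c(OC)c4)sc3n2)c1`, is not yet measured. It keeps the acrylamide-bearing side of compound 1 and the shared core, and differs from compound 1 only in the group on the five-membered ring: 3,4-dimethoxyphenyl in place of 4-ethylphenyl on an aromatic carbon.

For the measured compounds named here, no measured pair shows what this kind of exchange does on this core. Going by the values given here, the data therefore offer no direction for the step, and the expected change from this replacement is a 1.4-fold higher number from compound 1 to compound 3 (0.13 log units; within the scatter), small and within or close to the scatter. On that basis compound 3 is expected to give 3000 nM, with a range from 900 nM to 10000 nM.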

Compound 3, half-maximal inhibitory concentration: 42 nM
Estimate against measurement, compound 3: 71-fold (1.85 log units) above; the measured number lies below the stated range.
By their numbers in this assay, from the lowest: compound 3; then compound 1; then compound 2.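

In this assay, the aromatic carbon next to the ring sulfur proves to be a place where the aryl group matters a great deal: 3,4-dimethoxyphenyl in place of 4-ethylphenyl gives a 52-fold lower number from compound 1 to compound 3 (1.72 log units; beyond the scatter), with the acrylamide-bearing side and the shared core unchanged. For the compounds shown here, this is the first single-place comparison, and it shows that this exchange alone can move the number well beyond the scatter, although both groups hold one six-membered aromatic ring of carbon only and differ in their counts of heavy atoms and hydrogen-bond acceptors. Nothing measured here explains the step, so which feature of the exchange carries it remains unknown.

The compounds shown leave open whether both methoxy groups are needed, and whether a phenyl ring bearing a single methoxy group, a hydroxyl or an amine would do the same on this carbon. Compound 2 differs from the others in more than one place, so what the acrylamide-bearing side contributes also stays unread.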